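A few compounds are considered here, and "the series" means these few. Any claim that something is new, unique, unknown or untested is made for them only; others in the source may bear on it.

Measured in a functional assay on SK-OV-3 cells (Homo sapiens) for antiproliferative activity; a higher number here means a weaker inhibitor of growth, a lower number a stronger inhibitor of growth:
- compound 1 `c1ccc(-c2cc(-c3cccnc3)nc(-c3ccccn3)c2)cc1`: 49.6 ug/mL
- compound 2 `c1ccc(-c2cc(-c3cccs3)cc(-c3ccccn3)n2)nc1`: 0.12 ug/mL

Compound 2, at 0.12 ug/mL, holds the lower of the two numbers, and its gap to compound 1 lies beyond the scatter. Compound 3 `c1ccc(-c2cc(-c3cccs3)cc(-c3cccnc3)n2)nc1` has the same atoms as compound 2, joined differently: pyridin-3-yl in place of pyridin-2-yl on an aromatic carbon. Going by the values given here, no measured step isolates this change. Compound 1, which also carries pyridin-3-yl, gives 49.6 ug/mL, so a step beyond the scatter towards weaker growth inhibition in this assay is expected. The expected step is a 100-fold higher number from compound 2 to compound 3 (2.00 log units; beyond the scatter). Compound 3 is estimated at 12 ug/mL, with an expected range of 1.2 ug/mL to 70 ug/mL.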

Compound 3, concentration for 50% growth inhibition: 52 ug/mL
Compound 3: middle estimate off by 4.3-fold (0.64 log units), on the low side; the measured number falls inside the stated range.
By their numbers in this assay, from the lowest: compound 2; then compounds 1 and 3 (each within the scatter of the next).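

On the aromatic carbon next to the ring nitrogen, pyridin-3-yl in place of pyridin-2-yl gives a 430-fold higher number from compound 2 to compound 3 (2.64 log units; beyond the scatter) in this assay, so the way these same atoms are joined matters greatly at this position. With pyridin-3-yl present, thiophen-2-yl in place of phenyl gives a 1.0-fold higher number from compound 1 to compound 3 (0.02 log units; within the scatter), which leaves that exchange without a visible effect here. Nothing available explains the large step. Still open, on these data alone, is whether the thiophen-2-yl to phenyl exchange would also pass unseen with pyridin-2-yl present. Also open, as far as these compounds go, is whether an amine on the pyridin-2-yl group would keep the growth inhibition of compound 2.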